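The source may report more compounds than this note shows. Statements on the series, on what has been measured and on what is new or still open speak of the compounds shown alone.

Compound 2 `O=C(Nc1ccc(C(F)(F)F)cc1)Nc1cc2ncncc2cc1OCc1cccc(Cl)c1` carries a 4-(trifluoromethyl)phenyl group on one nitrogen of its urea; in an ADME assay on cells (Astrocyte, Homo sapiens) for cytotoxicity, read by WST assay, with a stated time of 72 h (a higher number here means a weaker inhibitor, a lower number a stronger inhibitor), compound 2 gives 8800 nM. Compound 3 `O=C(Nc1ccc(C(F)(F)F)cc1)Nc1cc2ncncc2cc1OCc1ccccc1` differs from it only in the core, by hydrogen in place of chloro on an aromatic carbon, and in this assay compound 3 gives 9200 nM, a step of a 1.0-fold higher number from compound 2 to compound 3 (0.02 log units; within the scatter). Compound 1 `O=C(Nc1cccc(Cl)c1)Nc1cc2ncncc2cc1OCc1cccc(Cl)c1` has the core of compound 2 but a different aryl group; in this assay compound 1 gives only > 10000 nM, which is a limit of the assay and not a number (the limit of > 10000 nM in this assay, at which 1 of the 3 values shown sits). That change, (3-chlorophenyl in place of 4-(trifluoromethyl)phenyl on an amide-type nitrogen), made a step of an at least 1.1-fold higher number from compound 2 to compound 1 (0.05 log units; that floor lies within the scatter). Compound 4 `O=C(Nc1cccc(Cl)c1)Nc1cc2ncncc2cc1OCc1ccccc1` applies the same change to compound 3, (3-chlorophenyl in place of 4-(trifluoromethyl)phenyl on an amide-type nitrogen), at an identical place. The step from compound 3 to compound 4 is expected to be a 1.3-fold higher number from compound 3 to compound 4 (0.12 log units; within the scatter), resting on the measured step from compound 2 to compound 1. Compound 4 is therefore estimated at 12000 nM, between 7000 nM and 25000 nM.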

Compound 4, half-maximal inhibitory concentration: 7400 nM
For compound 4 the middle estimate is 1.6-fold (0.21 log units) above the measured one; low and high end bracket the measured number.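

In this assay, 3-chlorophenyl in place of 4-(trifluoromethyl)phenyl gives a 1.2-fold lower number from compound 3 to compound 4 (0.09 log units; within the scatter), and this can be set beside the same change on the core of compound 2: the same change on two cores in this assay, an at least 1.1-fold higher number (0.05 log units; that floor lies within the scatter) from compound 2 to compound 1 and a 1.2-fold lower number (0.09 log units; within the scatter) from compound 3 to compound 4; the limit leaves it open whether they differ

Hydrogen in place of chloro on an aromatic carbon gives an at least 1.3-fold lower number from compound 1 to compound 4 (0.13 log units; that floor lies within the scatter), and this change also has an earlier counterpart: the same change on two cores in this assay, a 1.0-fold higher number (0.02 log units; within the scatter) from compound 2 to compound 3 and an at least 1.3-fold lower number (0.13 log units; that floor lies within the scatter) from compound 1 to compound 4; the limit leaves it open whether they differ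

Compound 1 gives > 10000 nM, which is a limit of the assay and not a number, so these pairs show neither that either change carries over unchanged from one core to the other nor that it does not.

The compounds shown leave open how this assay would read with an amine or a carboxylic acid in place of the 3-chlorophenyl group. They also leave open the effect of a longer chain in place of the hydrogen or chloro on the aromatic carbon.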